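Taking the side chain off compound 2

The source may hold more compounds than are shown below. What is called first, only, known or untested is meant among the compounds shown, and "the series" means these compounds.

compound 1 `CC(C)(C)C1=CC(=O)C=C(NCCC(=O)O)C1=O`: 47100 nM
compound 2 `CC(C)(C)C1=CC(=O)C=C(NCC(=O)O)C1=O`: 132000 nM
compound 3 `CC1=CCC[C@H]2[C@](C)(CC3=CC(=O)C=CC3=O)[C@@H](C)CC[C@]12C`: 18100 nM

All three values come from a functional assay on HeLa cells (Homo sapiens) for cytotoxicity, read by MTT assay, with a stated time of 72 h; on this read-out lower numbers stand for stronger inhibition and higher numbers for weaker inhibition. Compound 2 has the highest number of the three, 132000 nM, which makes it the weakest inhibitor of this small set.

The next compound, compound 4 `CC(C)(C)C1=CC(=O)C=CC1=O`, has not yet been measured in this assay. Its structure differs from that of compound 2 as follows: hydrogen in place of (carboxymethyl)amino on a double-bonded ring carbon. In short, it has hydrogen in place of (carboxymethyl)amino on a double-bonded ring carbon.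

For the measured compounds named here, only one measured step touches this group: a 2.8-fold higher number from compound 1 to compound 2 (0.45 log units; beyond the scatter). That modest step changes the chain and keeps the group in place, whereas here the group leaves altogether, so it is only a loose guide to size. Going by the values given here, no measured pair shows the removal directly, and the direction is therefore a judgement. Compound 2 sits at the top of the range, while compound 3 reaches 18100 nM, so there is measured room below compound 2. A lower number is expected, in a step somewhat larger than the modest one. The expected change is a 4.4-fold lower number from compound 2 to compound 4 (0.64 log units; beyond the scatter). For compound 4 the estimated value is 30000 nM, with an expected range from 9000 nM to 100000 nM.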

Compound 4, half-maximal inhibitory concentration: 44100 nM
For compound 4 the middle estimate is 1.5-fold (0.17 log units) below the measured one, within the range that was stated.
By their numbers in this assay, from the lowest: compound 3; then compounds 4 and 1 (each within the scatter of the next); then compound 2.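

In this assay this position can now be read with only hydrogen on the double-bonded ring carbon. Replacing the (carboxymethyl)amino group with hydrogen gives a 3.0-fold lower number from compound 2 to compound 4 (0.48 log units; beyond the scatter) and shows that compound 2 carries a side chain that goes with a weaker result than no side chain at all. Replacing the (2-carboxyethyl)amino group with hydrogen gives a 1.1-fold lower number from compound 1 to compound 4 (0.03 log units; within the scatter) and so leaves compound 1 and compound 4 indistinguishable, which means that the longer of the two chains offers no measurable gain over hydrogen, and no measurement here explains either step.

From the compounds shown here alone, it remains open whether a plain amine on this ring carbon, with no carboxylic acid, would behave like hydrogen or like the two acid-bearing chains, and whether a chain longer than (2-carboxyethyl)amino would give a lower number. The tert-butyl group is also the same in compound 1, compound 2 and compound 4, so these comparisons cannot say how a smaller group such as methyl would fare in its place.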